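Aryl replacement on the shared core: growth inhibition notes

The source may hold more compounds than are shown below. What is called first, only, known or untested is meant among the compounds shown, and "the series" means these compounds.

Measured so far:
compound 1, `O=Cc1ccc(-c2cn3ccnc3c(-c3ccc4ncn(C5CCCCC5)c4c3)n2)cc1`: 24.3%
compound 2, `Fc1ccc(-c2cn3ccnc3c(-c3ccc4ncn(C5CCCCC5)c4c3)n2)cc1`: 1.17%

Both compounds were run in a functional assay on DU-145 cells (Homo sapiens) for inhibition, read by sulforhodamine B assay, with a stated time of 48 h, tested at 10 uM; on this read-out higher numbers stand for more inhibition at the one concentration tested (going by the name of the read-out) and lower numbers for less inhibition. Going by the values given here, compound 2 gives the lower of the two numbers and compound 1 sits above it; the single measured step, a number 23.1 percentage points lower from compound 1 to compound 2 (beyond the scatter), is the only change characterised so far on this ring. Compound 3, `c1cn2cc(-c3ccsc3)nc(-c3ccc4ncn(C5CCCCC5)c4c3)c2n1`, carries the change (thiophen-3-yl in place of 4-fluorophenyl on an aromatic carbon). Among the compounds with values here, no measured step exchanges a six-membered aromatic ring for a five-membered one, so the one known step offers no direct guide; it shows only that altering the group on this ring can move the read-out by a modest amount. With compound 2 at the bottom of the range, a fall of any size has little room, while a rise of modest size is as plausible as no change. The estimate for compound 3 is therefore 8%, with a range of -5% to 25%. The expected step is a number 6.8 percentage points higher from compound 2 to compound 3 (within the scatter), which may well stay within the scatter.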

Compound 3, a percentage reported as inhibition, at one concentration (the size of the read-out at that concentration, not a potency): 1.36%
Compound 3: the middle estimate sits 6.6 percentage points above what was measured, within the range that was stated.
By their numbers in this assay, from the lowest: compounds 2 and 3 (each within the scatter of the next); then compound 1.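

In this assay, thiophen-3-yl in place of 4-fluorophenyl gives a number 0.2 percentage points higher from compound 2 to compound 3 (within the scatter), so at this position, on an aromatic carbon of the shared core, a five-membered aromatic ring with sulfur cannot be told apart from the six-membered fluorinated ring. Set against the formyl-bearing ring, the same thiophen-3-yl group gives a number 22.9 percentage points lower from compound 1 to compound 3 (beyond the scatter), which leaves compound 1 as the only one of the three that stands clear of the others, and shows that this separation holds for two different replacements of 4-formylphenyl rather than for the fluoro group alone. No supporting data bear on why the numbers fall this way.

Open, as far as these compounds go, is whether the higher number of compound 1 belongs to the formyl group itself, or whether a nitrile, a carboxylic acid or an amine on the same phenyl ring would read alike. Also open is how a pyridine ring would read at this position, and how any of these compounds would behave at concentrations other than the single one reported here.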